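This account rests on a few compounds, and the source may have more. Where it says the series, first, only, none or still open, it means among the compounds named here.

Measured so far:

Compound 1, `CC[C@@H](C)[C@H](NC(=O)c1ccc(C(CC)(CC)c2ccc(OCC(=O)C(C)(C)C)c(C)c2)n1CC)C(=O)O` — 10 nM in an assay on HL-60 cells for agonist activity at vitamin D3 receptor (Homo sapiens), read by microscopy, with a stated time of 96 h; a higher number here means that more compound is needed for the effect, a lower number that less compound is needed
Compound 2, `CCn1c(C(=O)N(C)CC(=O)O)ccc1C(CC)(CC)c1ccc(OCC(=O)C(C)(C)C)c(C)c1` — 1390 nM in this assay
Compound 3, `CC[C@@H](C)[C@H](NC(=O)c1ccc(C(CC)(CC)c2ccc(OCC(O)C(C)(C)C)c(C)c2)n1CC)C(=O)O` — 2.3 nM in this assay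

Compound 2 differs from compound 1 by one change, ((carboxymethyl)(methyl)amino in place of (1-carboxy-2-methylbutyl)amino on a carbonyl carbon), and the result was a 140-fold higher number from compound 1 to compound 2 (2.14 log units; beyond the scatter). Compound 3 differs from compound 1 in another place, (1-hydroxy-2,2-dimethylpropyl in place of (tert-butyl)carbonyl on a saturated chain carbon bound to an oxygen on an aromatic ring), which gave a 4.3-fold lower number from compound 1 to compound 3 (0.64 log units; beyond the scatter). Compound 4, `CCn1c(C(=O)N(C)CC(=O)O)ccc1C(CC)(CC)c1ccc(OCC(O)C(C)(C)C)c(C)c1`, has not yet been measured in this assay. It is built from compound 3 by the same change that led from compound 1 to compound 2, namely ((carboxymethyl)(methyl)amino in place of (1-carboxy-2-methylbutyl)amino on a carbonyl carbon), in the same place. Since that change on the core of compound 1 produced a 140-fold higher number from compound 1 to compound 2 (2.14 log units; beyond the scatter), a step of similar size is expected here, a 130-fold higher number from compound 3 to compound 4 (2.12 log units; beyond the scatter), so that compound 4 is estimated at about 300 nM, likely between 80 nM and 1200 nM. This rests on a single earlier example, so the uncertainty is considerable.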

Compound 4, half-maximal effective concentration: 740 nM
Compound 4: middle estimate off by 2.5-fold (0.39 log units), on the low side, and the stated range covers the measured number.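

Replacing (1-carboxy-2-methylbutyl)amino with (carboxymethyl)(methyl)amino in this assay gives a 320-fold higher number from compound 3 to compound 4 (2.51 log units; beyond the scatter), and this large step carries over between the two cores: the same change on two cores in this assay, a 140-fold higher number (2.14 log units; beyond the scatter) from compound 1 to compound 2 and a 320-fold higher number (2.51 log units; beyond the scatter) from compound 3 to compound 4, 2.3-fold (0.36 log units) apart, within the scatter of two such steps. Replacing (tert-butyl)carbonyl with 1-hydroxy-2,2-dimethylpropyl gives a 1.9-fold lower number from compound 2 to compound 4 (0.27 log units; within the scatter), yet the two steps for this change do not clearly differ: the same change on two cores in this assay, a 4.3-fold lower number (0.64 log units; beyond the scatter) from compound 1 to compound 3 and a 1.9-fold lower number (0.27 log units; within the scatter) from compound 2 to compound 4, 2.3-fold (0.36 log units) apart, within the scatter of two such steps. Going by these compounds alone, these are only two cores, so the steps show agreement within this small set, not a rule for other cores, and they give no reason for the size of either step.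

Going by these compounds, the swap on the carbonyl carbon alters both the chain and the methyl group on the nitrogen, so their separate contributions remain open. Also open, on these data alone, is how a plain (carboxymethyl)amino group or a longer chain ending in a carboxylic acid would read.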